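This account rests on a few compounds, and the source may have more. Where it says the series, first, only, none or still open, it means among the compounds named here.

Among the measured compounds shown here, compound 2 `CC(C)(N)CC(=O)N[C@@H]1CCc2ccccc2N(Cc2ccc(-c3ccccc3C(=O)O)cc2)C1=O` stands at the highest of the two numbers so far recorded in a functional assay (Pituitary gland cell) with Rattus norvegicus as the target; on this read-out higher numbers stand for an effect only at larger amounts of compound and lower numbers for an effect already at smaller amounts: in this assay compound 2 gives 3 uM, while compound 1 `CC(O)Cn1nnnc1-c1ccccc1-c1ccc(CN2C(=O)[C@H](NC(=O)CC(C)(C)N)CCc3ccccc32)cc1` gives 0.05 uM. For the measured compounds named here, the only measured step that bears on the present question is the one in which carboxy replaced 1-(2-hydroxypropyl)-1H-tetrazol-5-yl on an aromatic carbon, giving a 60-fold higher number from compound 1 to compound 2 (1.78 log units; beyond the scatter); that step shows how strongly this assay responds to what sits on that aromatic carbon of compound 2. Compound 3 `Cc1ccccc1-c1ccc(CN2C(=O)[C@H](NC(=O)CC(C)(C)N)CCc3ccccc32)cc1` goes one step further, with the change (methyl in place of carboxy on an aromatic carbon). Nothing measured here tells directly what a methyl group does on that carbon, so the expectation rests on the step already seen: the acid was itself a weaker substituent than the tetrazole, and taking it away altogether is expected to push the number further up, giving a 6.7-fold higher number from compound 2 to compound 3 (0.82 log units; beyond the scatter), a step beyond the scatter. Compound 3 is therefore estimated to give 20 uM in this assay, within a range from 3 uM to 100 uM.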

Compound 3, concentration for half-maximal effect: 1 uM
Compound 3: the middle estimate sits 20-fold (1.30 log units) above what was measured, outside the stated range (below it).
By their numbers in this assay, from the lowest: compound 1; then compound 3; then compound 2.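

In this assay, replacing 2-carboxyphenyl with 2-methylphenyl gives a 3.0-fold lower number from compound 2 to compound 3 (0.48 log units; beyond the scatter), so the carboxy group on this aromatic carbon, ortho to a large group, is not required for the effect, and a single methyl group does better here than carboxy. The 1-(2-hydroxypropyl)-1H-tetrazol-5-yl group nevertheless keeps a clear lead, since methyl in its place gives a 20-fold higher number from compound 1 to compound 3 (1.30 log units; beyond the scatter), and the three groups now form an order in which the number rises from that tetrazole through methyl to carboxy. No measurement here accounts for this order.

The compounds shown leave open whether the advantage of compound 1 lies in the tetrazole ring itself or in its 2-hydroxypropyl chain, a question that a plain 1H-tetrazol-5-yl group or a 1-methyl-1H-tetrazol-5-yl group on the same carbon would address. They also leave open where a bare hydrogen, a hydroxymethyl group or a primary carboxamide on that carbon would fall in this order.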